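Changing the Aryl Group on an Amide Nitrogen

The compounds below may be only part of what the source reports. "The series", "measured", "known", "first", "only" and "open" are said of these compounds alone.

compound 1 `CN(C)C(=O)c1cc2cnc(Nc3ccc(NC(=O)C4(C(=O)Nc5ccc(Cl)c(C(F)(F)F)c5)CC4)cc3)nc2n1C1CCCC1` gives 1.1%
compound 2 `COC(=O)c1cccc(NC(=O)C2(C(=O)Nc3ccc(Nc4ncc5cc(C(=O)N(C)C)n(C6CCCC6)c5n4)cc3)CC2)c1` gives 10.5%
compound 3 `CN(C)C(=O)c1cc2cnc(Nc3ccc(NC(=O)C4(C(=O)Nc5cccc(C(F)(F)F)c5)CC4)cc3)nc2n1C1CCCC1` gives 15.7%

In a functional assay on A549 cells (Homo sapiens) for inhibition, read by CCK-8 assay, with a stated time of 72 h, tested at 1 uM (on this read-out lower numbers stand for less inhibition of growth and higher numbers for more inhibition of growth at the one concentration tested), compound 3 gives 15.7% and lies within the scatter of compound 2 but clear of compound 1. For the measured compounds named here, compound 4 `CN(C)C(=O)c1cc2cnc(Nc3ccc(NC(=O)C4(C(=O)Nc5ccc(O)cc5)CC4)cc3)nc2n1C1CCCC1` carries 4-hydroxyphenyl in place of 3-(trifluoromethyl)phenyl on an amide-type nitrogen and no measured compound holds that group, so the guidance is only indirect. Changes to this same aryl group gave a number 9.4 percentage points higher from compound 1 to compound 2 (within the scatter) and a number 5.2 percentage points higher from compound 2 to compound 3 (within the scatter) and also a number 14.6 percentage points higher from compound 1 to compound 3 (beyond the scatter) as the largest step. Given those small steps, the expected step is a number 3.7 percentage points lower from compound 3 to compound 4 (within the scatter) and no shift beyond the scatter is expected. For compound 4 the estimate is 12% with an expected range from 0% to 28% in this assay.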

Compound 4, percent growth inhibition at one concentration: 93.6%
The estimate for compound 4 lay 81.6 percentage points below the measured number; the whole stated range lies below it.
By their numbers in this assay, from the lowest: compounds 1, 2 and 3 (each within the scatter of the next, the first and the last beyond it); then compound 4.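

For the compounds shown here, this position on the amide-type nitrogen tolerates far larger swings than the earlier compounds showed: in this assay, 4-hydroxyphenyl brings a number 77.9 percentage points higher from compound 3 to compound 4 (beyond the scatter) and a number 83.1 percentage points higher from compound 2 to compound 4 (beyond the scatter) and a number 92.5 percentage points higher from compound 1 to compound 4 (beyond the scatter). The earlier aryl groups stayed close together at the low end, so this single change of aryl group separates compound 4 from all three. No available evidence bears on this jump. On these data alone, whether the hydroxy group itself carries the gain stays open, as does what a methoxy group, an amine or a carboxylic acid on that ring would give.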